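This account rests on a few compounds, and the source may have more. Where it says the series, first, only, none or still open, it means among the compounds named here.

Of the compounds shown here, three that share one core have been measured in a functional assay on MCF7 cells (Homo sapiens) for cytotoxicity, read by neutral red uptake, with a stated time of 3 days; a higher number here means a weaker inhibitor, a lower number a stronger inhibitor. Compound 1 `CCCCc1c(F)c(N)c2c(=O)cc(-c3ccc(N)c(F)c3)oc2c1F` gives 8800 nM, compound 2 `C[S+]([O-])c1c(F)c(N)c2c(=O)cc(-c3ccc(N)c(F)c3)oc2c1F` gives 2500 nM, and compound 3 `Nc1ccc(-c2cc(=O)c3c(N)c(F)c(CO)c(F)c3o2)cc1F` gives 62 nM. The step of a 3.5-fold lower number from compound 1 to compound 2 (0.55 log units; beyond the scatter) is modest, whereas a 140-fold lower number from compound 1 to compound 3 (2.15 log units; beyond the scatter) and a 40-fold lower number from compound 2 to compound 3 (1.61 log units; beyond the scatter) are large, and compound 3 therefore stands lowest of the three numbers, with compound 2 nearest and compound 1 furthest.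

Compound 4 `[N-]=[N+]=Nc1c(F)c(N)c2c(=O)cc(-c3ccc(N)c(F)c3)oc2c1F` differs from compound 3 by azido in place of hydroxymethyl on an aromatic carbon. The measured steps that bear on this change are a 140-fold lower number from compound 1 to compound 3 (2.15 log units; beyond the scatter) and a 40-fold lower number from compound 2 to compound 3 (1.61 log units; beyond the scatter), both of which exchanged a group on the same aromatic carbon for hydroxymethyl and both of which brought large falls. Every group other than hydroxymethyl at this carbon has so far given a higher number in this assay, so the expectation for compound 4 is a step upward of a 19-fold higher number from compound 3 to compound 4 (1.29 log units; beyond the scatter), beyond the scatter. Compound 4 is accordingly estimated at 1200 nM, with a range from 250 nM to 6000 nM.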

Compound 4, half-maximal inhibitory concentration: 460 nM
For compound 4 the middle estimate is 2.6-fold (0.42 log units) above the measured one, within the range that was stated.
By their numbers in this assay, from the lowest: compound 3; then compound 4; then compound 2; then compound 1.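

Moving from hydroxymethyl to azido on this aromatic carbon, ortho to two fluoro groups, gives a 7.4-fold higher number from compound 3 to compound 4 (0.87 log units; beyond the scatter) in this assay and so a modest rise, which leaves hydroxymethyl with the lowest number of the four. The other two steps show that azido also sits well below the earlier groups: a 5.4-fold lower number from compound 2 to compound 4 (0.74 log units; beyond the scatter) is modest and a 19-fold lower number from compound 1 to compound 4 (1.28 log units; beyond the scatter) is large. A low number at this carbon therefore does not depend on hydroxymethyl alone, since azido, with 0 hydrogen-bond donors, comes much closer to it than butyl does.

Nothing measured here explains why these groups differ. Also open, from the compounds shown here alone, is where an amine, a carboxylic acid or a methoxy group on this carbon would fall relative to hydroxymethyl and azido.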